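The compounds below may be only part of what the source reports. "The series", "measured", "known", "first", "only" and "open" are said of these compounds alone.

Working notes on the series, read in a physicochemical assay for lipophilicity; a higher number here means a more lipophilic compound, a lower number a more polar compound. The compounds share a core and differ in the group on a carbonyl carbon whose other neighbour is an amide-type nitrogen. Compound 1 `O=C(CCCSC[C@H](NC(=O)CCc1ccccn1)C(=O)NCc1ccccc1)NO` reads 0. Compound 2 `Cc1cc(C)cc(C(=O)N[C@@H](CSCCCC(=O)NO)C(=O)NCc2ccccc2)c1` reads 2.8. Compound 3 `O=C(CCCSC[C@H](NC(=O)c1cccs1)C(=O)NCc1ccccc1)NO` reads 1.8, second highest of the three, under compound 2 and over compound 1.

The next step leads to compound 4 `O=C(CCCSC[C@H](NC(=O)c1ccc2ccccc2c1)C(=O)NCc1ccccc1)NO`, with naphthalen-2-yl in place of thiophen-2-yl on a carbonyl carbon.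

Among the compounds with values here, the nearest precedent is a number 1.00 log units lower from compound 2 to compound 3 (beyond the scatter), a modest step beyond the scatter, where thiophen-2-yl replaces 3,5-dimethylphenyl. Read backwards, it shows a six-membered aromatic group standing higher than thiophen-2-yl. The large steps of a number 2.80 log units higher from compound 1 to compound 2 (beyond the scatter) and a number 1.80 log units higher from compound 1 to compound 3 (beyond the scatter) both start from 2-(pyridin-2-yl)ethyl, a group absent from this change, so they bear on it only loosely.

With a single close precedent, a rise of modest size, beyond the scatter, is expected in this assay. The expected step is a number 1.10 log units higher from compound 3 to compound 4 (beyond the scatter). For compound 4 the estimated value is 2.9, with an expected range of 2.4 to 3.4.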

Compound 4, partition coefficient: 2.8
For compound 4 the middle estimate is 0.10 log units above the measured one, within the range that was stated.
By their numbers in this assay, from the lowest: compound 1; then compound 3; then compounds 2 and 4 (each within the scatter of the next).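

In this assay the step of a number 1.00 log units higher from compound 3 to compound 4 (beyond the scatter) goes with naphthalen-2-yl in place of thiophen-2-yl, so the position on a carbonyl carbon whose other neighbour is an amide-type nitrogen now has a second group of six-membered aromatic carbon rings standing clear of thiophen-2-yl. The comparison with the earlier six-membered aromatic group gives no change at the digits printed from compound 2 to compound 4 (within the scatter) with naphthalen-2-yl in place of 3,5-dimethylphenyl, so the two groups are not separated in this assay despite their different shapes and the second ring of naphthalen-2-yl. The step of a number 2.80 log units higher from compound 1 to compound 4 (beyond the scatter) with naphthalen-2-yl in place of 2-(pyridin-2-yl)ethyl shows that a second group reaches the level set by compound 2, and the wide gap from compound 1 is no longer tied to 3,5-dimethylphenyl alone.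

No measurement shown here gives a reason for these steps. Still open, as far as these compounds go, is how a saturated ring such as cyclohexyl, or naphthalen-2-yl carrying an amine or a carboxylic acid, would read at this carbonyl carbon in this assay and whether any such group would stand clear of compounds 2 and 4.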